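A few compounds are considered here, and "the series" means these few. Any claim that something is new, unique, unknown or untested is made for them only; others in the source may bear on it.

In an assay on membranes from brain for displacement of a labelled ligand from Neuronal acetylcholine receptor; alpha4/beta2 (Rattus norvegicus) (a higher number here means a weaker inhibitor, a lower number a stronger inhibitor), compound 2 `Cc1cncc(OC[C@@H]2CCCN2C)c1` gives 0.48 nM. Within the data shown here, only one other compound has been measured: compound 1 `CN1CCC[C@H]1COc1cnccc1Br`, which in this assay gives 28 nM, a higher number that lies beyond the scatter, so compound 2 stands lowest of the two. Compound 3 `CN1CCC[C@H]1COc1cncc([N+](=O)[O-])c1` is not yet measured in this assay. It differs from compound 2 in a single place: nitro in place of methyl on an aromatic carbon. Among the measured compounds shown here, no step between two measured compounds shows what this exchange does. Compound 1 and compound 2 differ in another place, so their gap offers no direct guide. The estimate rests on the low number of compound 2 at 0.48 nM and expects the exchange to leave the number close by, with a step of a 1.4-fold lower number from compound 2 to compound 3 (0.14 log units; within the scatter) that need not exceed the scatter. For compound 3 in this assay the expected value is 0.35 nM, in a range from 0.08 nM to 1.5 nM.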

Compound 3, inhibition constant: 4.65 nM
The estimate for compound 3 lay 13-fold (1.12 log units) below the measured number, and the stated range ends below it.
By their numbers in this assay, from the lowest: compound 2; then compound 3; then compound 1.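

In this assay, among these compounds, the aromatic carbon two atoms from the ring nitrogen proves sensitive to what it carries: nitro in place of methyl gives a 9.7-fold higher number from compound 2 to compound 3 (0.99 log units; beyond the scatter), the first single exchange that can be read. The step is beyond the scatter, yet compound 3 still gives 4.65 nM, so this place accepts nitro with a modest loss rather than a collapse of binding. Nothing at hand explains why the number rises.

Going by these compounds, with only methyl and nitro compared at this place, the step cannot be extended to other groups, and whether an amine, a carboxylic acid or a longer chain would stay near compound 2 or compound 3 remains open. On these data alone, whether the same exchange on another ring carbon would give a similar step also stays open.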